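Amine swap on the side chain: diethylamino to pyrrolidin-1-yl

The source may hold more compounds than are shown below. What is called first, only, known or untested is meant among the compounds shown, and "the series" means these compounds.

Measured in a functional assay on MGC-803 cells (Homo sapiens) for inhibition; a higher number here means a weaker inhibitor, a lower number a stronger inhibitor:
compound 1 `O=C(CC(CC(=O)NC1Cc2ccccc2C1)c1ccc(Cl)cc1)NCCN1CCCCC1`: 89100 nM
compound 2 `CCN(CC)CCNC(=O)CC(CC(=O)NC1Cc2ccccc2C1)c1ccc(Cl)cc1`: > 100000 nM (a limit)

Compound 2 stands at the limit of > 100000 nM in this assay, at which 1 of the 2 values shown sits. That reading is a limit and not a number, so any step starting from compound 2 has an open size.

The next compound is compound 3 `O=C(CC(CC(=O)NC1Cc2ccccc2C1)c1ccc(Cl)cc1)NCCN1CCCC1`. The change is pyrrolidin-1-yl in place of diethylamino on a saturated chain carbon, two bonds along the chain from an amide-type nitrogen.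

For the measured compounds named here, one measured step bears on this, at the same place: an at least 1.1-fold higher number from compound 1 to compound 2 (0.05 log units; that floor lies within the scatter), with diethylamino in place of piperidin-1-yl. It is a single pair, and it shows only a floor on the size of the step. Putting a ring back at that place leads to the expectation of a small move to a lower number in this assay, with compound 3 landing in the region of compound 1 at 89100 nM. A move beyond the scatter is not firmly expected. The expected step is an at least 1.2-fold lower number from compound 2 to compound 3 (0.09 log units; that floor lies within the scatter). For compound 3 the estimated value is 80000 nM, with an expected range of 35000 nM to 100000 nM.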

Compound 3, half-maximal inhibitory concentration: > 100000 nM
Compound 3 gave a limit, no number (the forecaster's own chance of this, stated with the estimate: 35%); middle value at least 1.2-fold (0.09 log units) from the limit.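

In this assay compound 3 gives > 100000 nM, a limit and not a number, so the step from the diethylamino compound cannot be read. Pyrrolidin-1-yl in place of piperidin-1-yl gives an at least 1.1-fold higher number from compound 1 to compound 3 (0.05 log units; that floor lies within the scatter), so only a floor on the size of this ring change is known. The new point is that a ring at this place does not by itself bring the reading back to a number, as pyrrolidin-1-yl and the open-chain diethylamino both end at the same limit: the limit of > 100000 nM in this assay, at which 2 of the 3 values shown sit.

For the compounds shown here, compound 1 at 89100 nM remains the only number, and whether any change at this place moves the reading beyond the scatter stays open. Also open, going by these compounds, are morpholin-4-yl or 4-methylpiperazin-1-yl at this place and a longer chain carrying the piperidin-1-yl, which could show whether the amine side chain has any readable effect on the series in this assay.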